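The source may report more compounds than this note shows. Statements on the series, on what has been measured and on what is new or still open speak of the compounds shown alone.

Measured in an ADME assay on MT4 cells (Homo sapiens) for cytotoxicity, read by MTT assay, with a stated time of 5 days; on this read-out higher numbers stand for lower toxicity in this test and lower numbers for higher toxicity in this test:
compound 1 `CCNc1cc(Oc2c(OC)cc3cc(C#N)ccc3c2OC)nc(Nc2ccc(C#N)cc2)n1`: > 125000 nM
compound 2 `COc1cc2cc(C#N)ccc2c(OC)c1Oc1cc(NC2CCOC2)nc(Nc2ccc(C#N)cc2)n1`: > 125000 nM
compound 3 `COc1cc2cc(C#N)ccc2c(OC)c1Oc1cc(NCC2CCOC2)nc(Nc2ccc(C#N)cc2)n1`: > 125000 nM

Each of these entries is a limit of the assay and not a number. Compound 3 stands at the limit of > 125000 nM in this assay, at which 3 of the 3 values shown sit.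

Compound 4 `COc1cc2cc(C#N)ccc2c(OC)c1Oc1cc(NCCCCO)nc(Nc2ccc(C#N)cc2)n1` differs from compound 3 in one place: 3-hydroxypropyl in place of oxolan-3-yl on a saturated chain carbon bound to a nitrogen on an aromatic ring. Here 3-hydroxypropyl takes the place of oxolan-3-yl on a saturated chain carbon bound to a nitrogen on an aromatic ring, so (oxolan-3-yl)methyl becomes 4-hydroxybutyl.

The measured changes at this substituent are a step that the two limits leave unreadable from compound 1 to compound 3, a step that the two limits leave unreadable from compound 2 to compound 3 and a step that the two limits leave unreadable from compound 1 to compound 2. None has a readable size, yet all three compounds remain at the limit. Among the compounds with values here, no measured compound carries the 4-hydroxybutyl group, so this support is indirect. On that basis, no step beyond the usual scatter is expected in this assay, and no direction can be favoured.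

The expected change is a number no higher from compound 3 to compound 4 (the limit leaves the size open). For compound 4, the estimated value is 125000 nM, with an expected range of 45000 nM to 250000 nM.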

Compound 4, half-maximal cytotoxic concentration: 39100 nM
Compound 4: the middle estimate sits 3.2-fold (0.50 log units) above what was measured, and the stated range ends above it.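

In this assay the group on the nitrogen proves able to move the read-out: exchanging (oxolan-3-yl)methyl for 4-hydroxybutyl gives an at least 3.1-fold lower number from compound 3 to compound 4 (0.50 log units; beyond the scatter) and thus higher toxicity in this test. Set against the other two substituents, 4-hydroxybutyl gives an at least 3.1-fold lower number from compound 2 to compound 4 (0.50 log units; beyond the scatter) and an at least 3.1-fold lower number from compound 1 to compound 4 (0.50 log units; beyond the scatter) in the same direction. Compound 4 alone carries a number, and the steps among compound 1, compound 2 and compound 3 cannot be read, since each of these rests at a limit of the assay: the limit of > 125000 nM in this assay, at which 3 of the 4 values shown sit.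

The change from compound 3 to compound 4 both removes a ring and adds 1 hydrogen-bond donor, and the compounds shown do not separate the two. From the compounds shown here alone, whether a 4-methoxybutyl group, a 4-aminobutyl group or a longer 5-hydroxypentyl chain on the nitrogen would return the number to the limit or lower it further remains open.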